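A few compounds are considered here, and "the series" means these few. Any claim that something is new, unique, unknown or untested is made for them only; others in the source may bear on it.

Compound 1 `CCCCC1=C(C(=O)OCC)C(c2cccc([N+](=O)[O-])c2)C(C(=O)OCC)=C(C)N1`: 20 nM
Compound 2 `CCOC(=O)C1=C(C)NC(COC(C)=O)=C(C(=O)OCC)C1c1cccc([N+](=O)[O-])c1`: 10 nM
Compound 3 `CCOC(=O)C1=C(C)NC(CN2CCN(c3ccccc3)CC2)=C(C(=O)OCC)C1c1cccc([N+](=O)[O-])c1`: 630 nM

In a functional assay on HEK293 cells for antagonist activity at Voltage-dependent L-type calcium channel subunit alpha-1C (Oryctolagus cuniculus), read by FLIPR (a higher number here means a weaker inhibitor, a lower number a stronger inhibitor), compound 2 gives 10 nM, the lowest number among the three, although compound 1 sits within the scatter of it, as the step of a 2.0-fold lower number from compound 1 to compound 2 (0.30 log units; within the scatter) shows. Compound 3 stands far off, the step of a 63-fold higher number from compound 2 to compound 3 (1.80 log units; beyond the scatter) being large.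

Compound 4 `CCOC(=O)C1=C(C)NC(/C=C/c2ccc([N+](=O)[O-])cc2)=C(C(=O)OCC)C1c1cccc([N+](=O)[O-])c1` differs from compound 2 in one place: 2-(4-nitrophenyl)ethenyl in place of acetoxymethyl on a double-bonded ring carbon. For the measured compounds named here, two measured steps bear on this. Replacing the propyl of compound 1 by a small acetoxy left the number essentially unchanged, a 2.0-fold lower number from compound 1 to compound 2 (0.30 log units; within the scatter). Replacing it by the bulkier 4-phenylpiperazin-1-yl, however, raised the number sharply, a 32-fold higher number from compound 1 to compound 3 (1.50 log units; beyond the scatter), and the corresponding step from compound 2, a 63-fold higher number from compound 2 to compound 3 (1.80 log units; beyond the scatter), was larger still. The group entering in compound 4 is, by the counts given, far larger than the acetoxymethyl it replaces, so a clear rise in this assay is expected, though its extent beyond the scatter is uncertain. Compound 4 is therefore estimated at 150 nM, within 30 nM to 800 nM, an expected step of a 15-fold higher number from compound 2 to compound 4 (1.18 log units; beyond the scatter).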

Compound 4, half-maximal inhibitory concentration: 1940 nM
The estimate for compound 4 lay 13-fold (1.11 log units) below the measured number; measured number above the stated range.
By their numbers in this assay, from the lowest: compounds 2 and 1 (each within the scatter of the next); then compound 3; then compound 4.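

In this assay, the double-bonded ring carbon next to the ring nitrogen proves to tolerate 2-(4-nitrophenyl)ethenyl poorly, with a 190-fold higher number from compound 2 to compound 4 (2.29 log units; beyond the scatter) and a 97-fold higher number from compound 1 to compound 4 (1.99 log units; beyond the scatter), both large. Compound 3 gives 630 nM and compound 4 gives 1940 nM, so a large rise at this position is not confined to the 4-phenylpiperazin-1-yl group and also occurs with an ethenyl-linked aromatic ring. The data shown offer no measured explanation for either rise.

The compounds shown leave open whether the rise follows the size of the entering group, the ethenyl link or the nitro group, as all three enter together. A plain 2-phenylethenyl group, or a small amine or carboxylic acid at this carbon, would help to separate these possibilities.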